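A few compounds are considered here, and "the series" means these few. Any claim that something is new, unique, unknown or untested is made for them only; others in the source may bear on it.

Working notes on cytotoxicity in a functional assay on Vero cells (Chlorocebus sabaeus) for cytotoxicity; a lower number here means a stronger inhibitor, a higher number a weaker inhibitor. Two compounds are measured. Compound 1 `CS/C=C/c1nn(C2C[C@@H](O)[C@@H](CO)O2)c(=O)[nH]c1=O` gives 420 ug/mL in this assay. Among the compounds with values here, compound 2 `O=Cc1nn(C2C[C@@H](O)[C@@H](CO)O2)c(=O)[nH]c1=O` gives 180 ug/mL in this assay, the lowest of the two numbers; the only step measured, a 2.3-fold lower number from compound 1 to compound 2 (0.37 log units; beyond the scatter), ran with the formyl group replacing the 2-(methylsulfanyl)ethenyl group. Compound 3 `O=C(O)/C=C/c1nn(C2C[C@@H](O)[C@@H](CO)O2)c(=O)[nH]c1=O` is not yet measured. It differs from compound 2 as follows: 2-carboxyethenyl in place of formyl on an aromatic carbon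

Within the data shown here, only the step from compound 1 to compound 2 bears on this change, since it touches the same aromatic carbon and also exchanges a formyl for an ethenyl-type chain, though the carboxy end of the new chain has no measured counterpart. Because a 2.3-fold lower number from compound 1 to compound 2 (0.37 log units; beyond the scatter) was modest, the reverse-leaning change in compound 3 is expected to shift the number upward by a similarly modest amount, a 1.7-fold higher number from compound 2 to compound 3 (0.22 log units; within the scatter), with a wide range. Compound 3 is therefore estimated at 300 ug/mL in this assay, between 130 ug/mL and 700 ug/mL.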

Compound 3, concentration for 50% inhibition: > 500 ug/mL
Compound 3 was reported as a limit; the forecaster's own chance of this, stated with the estimate: 10%; at least 1.6-fold (0.22 log units) between middle value and limit.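

In this assay, compound 3 is reported only as a limit, > 500 ug/mL. At this aromatic carbon, 2-carboxyethenyl in place of formyl gives an at least 2.7-fold higher number from compound 2 to compound 3 (0.44 log units; beyond the scatter), so both chains measured here, 2-(methylsulfanyl)ethenyl and 2-carboxyethenyl, read higher than formyl, and compound 2 keeps the lowest number of the three. Exchanging the chain end gives an at least 1.1-fold higher number from compound 1 to compound 3 (0.07 log units; that floor lies within the scatter), and since that floor lies within the scatter, the carboxy and methylsulfanyl ends cannot be ranked.

Going by these compounds, the true size of both steps from compound 3 stays open, as only a floor is available: the limit of > 500 ug/mL in this assay, at which 1 of the 3 values shown sits. Also open is how a primary amide or methyl ester at the chain end, or an aminomethyl group on the aromatic carbon, would read in this assay.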